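The source may report more compounds than this note shows. Statements on the series, on what has been measured and on what is new or still open speak of the compounds shown alone.

Measured so far:
compound 1, `N=C(S)CCn1nc(-c2ccc(Cl)cc2)ccc1=O`: > 100 mg/kg
compound 2, `N=C(S)CCCCCCN1N=C(c2ccccc2)CCC1=O`: 58.8 mg/kg
compound 3, `N=C(S)CCCn1nc(-c2ccccc2)ccc1=O`: 31.9 mg/kg

All three were tested in a functional assay on the whole organism (stomach) with Rattus norvegicus as the target; on this read-out lower numbers stand for an effect already at smaller amounts and higher numbers for an effect only at larger amounts of compound. Compound 1 gives > 100 mg/kg in this assay, and this is a limit of the assay rather than a measured number. Compound 1 thus sits at the limit of > 100 mg/kg in this assay, at which 1 of the 3 values shown sits. Compound 2 gives 58.8 mg/kg and compound 3 gives 31.9 mg/kg. Compound 2 and compound 3 each received a number; compound 1 did not, so only a range is known for it.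

The next compound, compound 4 (`N=C(S)CCn1nc(-c2ccc(Cl)c(Cl)c2)ccc1=O`), differs from compound 1 in a single way: chloro in place of hydrogen on an aromatic carbon.

For the measured compounds named here, no pair of measured compounds differs in only one place, so no measured step shows what a change of this kind does in this assay. With compound 1 resting on a limit, the expectation for compound 4 can rest only on that limit. The step from compound 1 to compound 4 is expected to be a number no higher from compound 1 to compound 4 (the limit leaves the size open), that is, none beyond the scatter. Compound 4 is therefore expected to give 100 mg/kg in this assay, with a range from 30 mg/kg to 300 mg/kg.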

Compound 4, dose for half-maximal effect: 78.1 mg/kg
Beside the measured number, compound 4's estimate is 1.3-fold (0.11 log units) above it; the measured number falls inside the stated range.
By their numbers in this assay, from the lowest: compounds 3, 2 and 4 (each within the scatter of the next, the first and the last beyond it). At a limit, above all of these: compound 1.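

In this assay, compound 4 carries a second chloro group, ortho to the chloro group already present and meta to a large group, and this change moves the result from a limit to a measured number. Chloro in place of hydrogen at this position goes with an at least 1.2-fold lower number from compound 1 to compound 4 (0.10 log units; that floor lies within the scatter), so the change shows no sign of raising the number, but the lowering that can be proved is no larger than ordinary repeat variation. The true size of the step stays unknown because the value of compound 1 is a limit and not a number: the limit of > 100 mg/kg in this assay, at which 1 of the 4 values shown sits.

The compounds shown leave open whether a different group at this position, such as a fluoro or a methoxy group, would give a number like that of compound 4, or whether the hydrogen-to-chloro change itself is what matters. They also leave open whether the same chloro group would act in the same way on a compound with a longer chain, such as compound 3, and they offer no measured reason for any of these effects.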